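This account rests on a few compounds, and the source may have more. Where it says the series, first, only, none or still open, it means among the compounds named here.

In a functional assay on DU-145 cells (Homo sapiens) for antiproliferative activity, read by MTT assay, with a stated time of 72 h (a higher number here means a weaker inhibitor, a lower number a stronger inhibitor), three compounds on a shared core have been measured. Compound 1 `Cc1ccc(N(C)S(=O)(=O)C2CC3OC2C(c2ccc(NC(=O)CCCCCCC(=O)O)cc2)=C3c2ccc(O)cc2)cc1` reads > 100000 nM as a limit of the assay and not a number. Compound 2 `CCN(c1ccc(C)cc1)S(=O)(=O)C1CC2OC1C(c1ccc(NC(=O)CCCCCCC(=O)O)cc1)=C2c1ccc(O)cc1` gives 53500 nM and compound 3 `CCN(c1ccc(OC)cc1)S(=O)(=O)C1CC2OC1C(c1ccc(NC(=O)CCCCCCC(=O)O)cc1)=C2c1ccc(O)cc1` gives 24400 nM, the lower of the two actual numbers.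

Compound 4 `CCN(c1cccc(OC)c1)S(=O)(=O)C1CC2OC1C(c1ccc(NC(=O)CCCCCCC(=O)O)cc1)=C2c1ccc(O)cc1` is still unmeasured. It differs from compound 3 only in the place of the methoxy group: 3-methoxyphenyl in place of 4-methoxyphenyl on a sulfonamide nitrogen, which means 3-methoxyphenyl in place of 4-methoxyphenyl on a sulfonamide nitrogen. For the measured compounds named here, no measured pair makes this exact move. The closest guide is a 2.2-fold lower number from compound 2 to compound 3 (0.34 log units; beyond the scatter), where methoxy replaced methyl on an aromatic carbon. The larger at least 4.0-fold lower number from compound 1 to compound 3 (0.61 log units; beyond the scatter) rests on a limit and changes more of the group, so it says less here. Since the same atoms stay in compound 4, no step beyond the scatter is expected, and the direction is uncertain. The estimated change is a 1.2-fold higher number from compound 3 to compound 4 (0.09 log units; within the scatter) in this assay. For compound 4 the expected value is 30000 nM, with an estimated range from 12000 nM to 70000 nM.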

Compound 4, half-maximal inhibitory concentration: 71100 nM
Compound 4: middle estimate off by 2.4-fold (0.37 log units), on the low side; the whole stated range lies below it.
By their numbers in this assay, from the lowest: compound 3; then compounds 2 and 4 (each within the scatter of the next). At a limit, above all of these: compound 1.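

In this assay, the place of the methoxy group on the ring matters: 3-methoxyphenyl in place of 4-methoxyphenyl on a sulfonamide nitrogen, with the same atoms joined differently, gives a 2.9-fold higher number from compound 3 to compound 4 (0.46 log units; beyond the scatter). The lower number of compound 3 therefore goes with the 4-methoxyphenyl group and not with any methoxy-bearing ring, as 3-methoxyphenyl in place of 4-methylphenyl gives only a 1.3-fold higher number from compound 2 to compound 4 (0.12 log units; within the scatter). Compound 1 stands at a limit of the assay and not at a number, so the comparison reads only as an at least 1.4-fold lower number from compound 1 to compound 4 (0.14 log units; that floor lies within the scatter), which says little: the limit of > 100000 nM in this assay, at which 1 of the 4 values shown sits.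

The compounds shown leave open whether a 3-methylphenyl group would follow the same trend as the methoxy pair. On these data alone, how a 4-chlorophenyl group on this nitrogen, or a propyl group in place of the ethyl, would read also remains open.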